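The source may hold more compounds than are shown below. What is called first, only, known or untested is meant among the compounds shown, and "the series" means these compounds.

Measured compounds:
- Compound 1, `O=C(NCc1ccncc1)Nc1ccc(S(=O)(=O)c2ccccc2Cl)cc1`: in an assay on isolated protein for activation of Nicotinamide phosphoribosyltransferase (Homo sapiens) (on this read-out lower numbers stand for an effect already at smaller amounts and higher numbers for an effect only at larger amounts of compound), compound 1 gives 79 nM
- Compound 2, `CN(C)S(=O)(=O)c1ccc(NC(=O)NCc2ccncc2)cc1`: in this assay compound 2 gives 3110 nM

Among the measured compounds shown here, on this assay compound 2 stands at the highest of the two numbers; its nearest neighbour is compound 1, and the only measured step in this set, a 39-fold higher number from compound 1 to compound 2 (1.60 log units; beyond the scatter), came with dimethylamino in place of 2-chlorophenyl on a sulfonyl sulfur. Compound 3, `CCN(C1CCCC1)S(=O)(=O)c1ccc(NC(=O)NCc2ccncc2)cc1`, has not been measured. Its change from compound 2 is cyclopentyl(ethyl)amino in place of dimethylamino on a sulfonyl sulfur. For the measured compounds named here, the one step that bears on it is the large one from compound 1 to compound 2, which shows that the group on the sulfonyl sulfur matters strongly on this assay; compound 3 brings back a larger group there, though not the 2-chlorophenyl of compound 1. An intermediate number is therefore expected for compound 3, below compound 2 but not reaching compound 1, and compound 3 is estimated at 900 nM, with a range from 250 nM to 3500 nM. The expected step is a 3.5-fold lower number from compound 2 to compound 3 (0.54 log units; beyond the scatter).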

Compound 3, half-maximal effective concentration: 60 nM
Compound 3: the middle estimate sits 15-fold (1.18 log units) above what was measured; measured number outside the range, below it.
By their numbers in this assay, from the lowest: compounds 3 and 1 (each within the scatter of the next); then compound 2.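

In this assay the amino group on the sulfonyl sulfur is not what sets the high number of compound 2, since replacing dimethylamino with cyclopentyl(ethyl)amino keeps the nitrogen on the sulfur and still gives a 52-fold lower number from compound 2 to compound 3 (1.71 log units; beyond the scatter) as a large step. By the computed count this change adds carbon and one five-membered non-aromatic ring of carbon only, with no hydrogen-bond donors or acceptors on either side, so these additions are all that accompany the step. The 2-chlorophenyl group is also not needed to reach the low numbers of this set, as the exchange for cyclopentyl(ethyl)amino gives a 1.3-fold lower number from compound 1 to compound 3 (0.12 log units; within the scatter) and stays within the scatter, leaving compound 1 and compound 3 indistinguishable on this read-out.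

The compounds shown do not separate the ethyl part from the cyclopentyl part, so it remains open whether diethylamino, a piperidine ring or cyclopentylamino with its nitrogen hydrogen on the sulfonyl sulfur would go with a number like that of compound 3. Nothing available explains why the added carbon and ring go with so large a step.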